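Tertiary Amide Variation in a Stilbene Cinnamamide Series

The source may report more compounds than this note shows. Statements on the series, on what has been measured and on what is new or still open speak of the compounds shown alone.

Compound 1 `CCCCNC(=O)/C=C/c1c(/C=C/c2ccc(OC)cc2)cc(OC)cc1OC` gives 2080 nM in a functional assay on B16-F10 cells (Mus musculus) for inhibition, read by MTT assay, with a stated time of 48 h; on this read-out lower numbers stand for stronger inhibition and higher numbers for weaker inhibition.
Compound 2 `CCCCN(CCCC)C(=O)/C=C/c1c(/C=C/c2ccc(OC)cc2)cc(OC)cc1OC` gives 9030 nM in this assay.

Compound 2 stands highest of the two numbers, its nearest neighbour being compound 1, and the step of a 4.3-fold higher number from compound 1 to compound 2 (0.64 log units; beyond the scatter) is beyond the scatter. Compound 3 `COc1ccc(/C=C/c2cc(OC)cc(OC)c2/C=C/C(=O)N2CCC(c3ccccc3)CC2)cc1` differs from compound 2 by 4-phenylpiperidin-1-yl in place of dibutylamino on a carbonyl carbon. Within the data shown here, no measured step touches this exchange directly; the one known step, a 4.3-fold higher number from compound 1 to compound 2 (0.64 log units; beyond the scatter), concerns a hydrogen-to-butyl change and bears on it only loosely, since compound 3 keeps a fully substituted amide nitrogen. Compound 3 is therefore expected to stay near compound 2, with a 1.4-fold lower number from compound 2 to compound 3 (0.14 log units; within the scatter) within the scatter, at an estimated 6500 nM (range 2000 nM to 20000 nM).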

Compound 3, half-maximal inhibitory concentration: 9180 nM
Compound 3: the middle estimate sits 1.4-fold (0.15 log units) below what was measured; low and high end bracket the measured number.
By their numbers in this assay, from the lowest: compound 1; then compounds 2 and 3 (each within the scatter of the next).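

On the carbonyl carbon, the open-chain dibutylamino group and 4-phenylpiperidin-1-yl, which carries two rings, cannot be told apart in this assay (a 1.0-fold higher number from compound 2 to compound 3 (0.01 log units; within the scatter)). The butylamino group remains the only one of the three that separates from the others, now also against the ring-bearing group (a 4.4-fold higher number from compound 1 to compound 3 (0.64 log units; beyond the scatter)). No evidence is available to explain this result. Still open, going by these compounds, is whether a plain piperidine or a morpholine on the carbonyl carbon would stay level with compound 2 and compound 3. Equally open, on these data alone, is how a primary amide, with both amide hydrogens, would compare with compound 1.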